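Swapping the aryl group on the triazole nitrogen: compound 4

The compounds below may be only part of what the source reports. "The series", "measured", "known", "first", "only" and "open" are said of these compounds alone.

Measured so far:
- Compound 1 `CCc1ccc(-n2nc(-c3ccc(C(F)(F)F)cc3O)nc2-c2ccccc2O)cc1`: 95.4%
- Compound 2 `N#Cc1ccc(-n2nc(-c3ccc(C(F)(F)F)cc3O)nc2-c2ccccc2O)cc1`: 86.8%
- Compound 3 `Oc1cc(C(F)(F)F)ccc1-c1nc(-c2ccccc2O)n(-c2ccccc2F)n1`: 86.6%

These three share one core and differ only in the aryl group on the aromatic nitrogen. In a functional assay on PC-12 cells (Rattus norvegicus) for cytotoxicity, read by MTT assay, with stated times of 2 h and 24 h, tested at 5 uM (a higher number here means a stronger effect of the compound at the concentration tested, a lower number a weaker effect), compound 3 stands lowest of the three numbers, but the steps that lead to it, a number 0.2 percentage points lower from compound 2 to compound 3 (within the scatter) and a number 8.8 percentage points lower from compound 1 to compound 3 (within the scatter), are both within the scatter, so the three cannot be ordered.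

Compound 4 `Oc1cc(C(F)(F)F)ccc1-c1nc(-c2ccccc2O)n(-c2cccc(Cl)c2)n1` is not yet measured. It differs from compound 3 by 3-chlorophenyl in place of 2-fluorophenyl on an aromatic nitrogen. The two steps that bear on this place, a number 8.6 percentage points lower from compound 1 to compound 2 (within the scatter) and a number 8.8 percentage points lower from compound 1 to compound 3 (within the scatter), were both within the scatter, so no step beyond the scatter is expected in this assay. For compound 4 the expected value is 88%, with a range from 75% to 98%, an expected step of a number 1.4 percentage points higher from compound 3 to compound 4 (within the scatter).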

Compound 4, a percentage reported as activity, at one concentration (the size of the read-out at that concentration, not a potency): 92.7%
For compound 4 the middle estimate is 4.7 percentage points below the measured one; measured number inside the range.
By their numbers in this assay, from the lowest: compounds 3, 2, 4 and 1 (each within the scatter of the next).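

In this assay a chlorine-bearing ring at this aromatic nitrogen changes nothing beyond the scatter, with a number 6.1 percentage points higher from compound 3 to compound 4 (within the scatter) and a number 5.9 percentage points higher from compound 2 to compound 4 (within the scatter) and a number 2.7 percentage points lower from compound 1 to compound 4 (within the scatter). So 3-chlorophenyl stands with 2-fluorophenyl, 4-cyanophenyl and 4-ethylphenyl, and the four compounds still cannot be ordered. Nothing available explains why these four aryl groups read alike.

Still open, from the compounds shown here alone, is whether a phenyl ring carrying an amine or a carboxylic acid would step beyond the scatter. The same holds for a longer alkyl chain in place of the aryl group.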